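Estimating a 4-fluorophenyl analogue in the A-431 series

This account rests on a few compounds, and the source may have more. Where it says the series, first, only, none or still open, it means among the compounds named here.

Measured compounds:
compound 1, `C#Cc1cccc(Nc2ncnc3cc(OC)c(OCCCCC(=O)Nc4ccc(S(N)(=O)=O)cc4)cc23)c1`: 17700 nM
compound 2, `COc1cc2ncnc(Nc3cccc(Cl)c3)c2cc1OCCCCC(=O)Nc1ccc(S(N)(=O)=O)cc1`: 30400 nM

In a functional assay on A-431 cells (Homo sapiens) for antiproliferative activity, read by MTT assay, with a stated time of 72 h (on this read-out higher numbers stand for weaker inhibition and lower numbers for stronger inhibition), compound 1 gives 17700 nM. For the measured compounds named here, compound 2 has the highest of the two numbers in this assay, but the only measured step, a 1.7-fold higher number from compound 1 to compound 2 (0.23 log units; within the scatter), is within the scatter, so the two compounds are not separable on these numbers. Compound 3, `COc1cc2ncnc(Nc3ccc(F)cc3)c2cc1OCCCCC(=O)Nc1ccc(S(N)(=O)=O)cc1`, has not yet been measured; it differs from compound 2 by 4-fluorophenyl in place of 3-chlorophenyl on a nitrogen on an aromatic ring. No measured step touches this place in the same way: the one step shown, ethynyl to chloro, lies elsewhere on the same ring and was small. Nothing in the measured pair therefore supports a step of any size beyond the scatter, though the measured pair also gives no guarantee against one. Compound 3 is expected to give 45000 nM, within 12000 nM to 150000 nM, which is expected to be a step of a 1.5-fold higher number from compound 2 to compound 3 (0.17 log units; within the scatter).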

Compound 3, half-maximal inhibitory concentration: 18600 nM
Compound 3: middle estimate off by 2.4-fold (0.38 log units), on the high side; the range from low to high includes it.
By their numbers in this assay, from the lowest: compounds 1, 3 and 2 (each within the scatter of the next).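

In this assay the change from 3-chlorophenyl to 4-fluorophenyl on the nitrogen gives a 1.6-fold lower number from compound 2 to compound 3 (0.21 log units; within the scatter) and the change from 3-ethynylphenyl to 4-fluorophenyl gives a 1.1-fold higher number from compound 1 to compound 3 (0.02 log units; within the scatter) so neither step separates the compounds. The earlier pair had shown this only for ethynyl and chloro on the same ring carbon, whereas compound 3 carries a different halogen and a different substitution pattern, and all three compounds still remain within the scatter of one another. Nothing available on these compounds bears further on this result.

Compound 3 changes both the halogen and its place at once. 3-fluorophenyl and 4-chlorophenyl would be needed to tell those two changes apart. Going by these compounds, it also remains open whether an amine or a carboxylic acid on this ring, or a longer chain elsewhere in the molecule, would produce a step beyond the scatter.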